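The source may hold more compounds than are shown below. What is called first, only, known or untested is meant among the compounds shown, and "the series" means these compounds.

Compound 1 `CN(C(=O)c1cc2c(Cc3ccccc3)n[nH]c2cc1O)c1ccco1`: 2500 nM
Compound 2 `Cc1ccccc1Cc1n[nH]c2cc(O)c(C(=O)N(C)Cc3ccccc3)cc12`: "not determined" (no result reported)

Among the compounds with values here, in a functional assay on A2780 cells (Homo sapiens) for antiproliferative activity, read by resazurin assay, with a stated time of 72 h (a higher number here means a weaker inhibitor, a lower number a stronger inhibitor), compound 1 gives 2500 nM, the only number available so far. Compound 2 has no place on this scale, since for compound 2 the entry reads "not determined" (no result reported). Compound 3 `CN(Cc1ccccc1)C(=O)c1cc2c(CCc3ccccc3)n[nH]c2cc1O` is still to be measured. The structural change is benzyl in place of 2-methylphenyl on a saturated chain carbon bound to an aromatic carbon. In words, benzyl takes the place of 2-methylphenyl on a saturated chain carbon bound to an aromatic carbon, which, cut one bond further out, reads 2-methylbenzyl to phenethyl. The two compounds have the same atoms, joined differently. Within the data shown here, with no number for compound 2, the data show no step to lean on, so no shift in either direction is expected in this assay beyond the scatter. The estimate therefore stays close to compound 1 at 2500 nM, with a wide margin. For compound 3 the expected value is 1800 nM, with an estimated range of 350 nM to 9000 nM.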

Compound 3, half-maximal inhibitory concentration: 4600 nM
Compound 3: the middle estimate sits 2.6-fold (0.41 log units) below what was measured, and the stated range covers the measured number.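

Compound 2 has no reported number to set against compound 3, so no step can be read between them. As far as these compounds go, whether changing 2-methylbenzyl to phenethyl alters antiproliferative activity therefore stays open, and no other data here bear on this result.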